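Trimming the Pyridine Ether Side Chain on a Xanthine Core

The source may report more compounds than this note shows. Statements on the series, on what has been measured and on what is new or still open speak of the compounds shown alone.

Measured compounds:
compound 1, `CCCn1c(=O)c2nc(-c3ccc(OCC(=O)Nc4ccc(F)cc4)nc3)[nH]c2n(CCC)c1=O`: 4.8 nM
compound 2, `CCCn1c(=O)c2nc(-c3cc(OCC(=O)O)no3)[nH]c2n(CCC)c1=O`: 18 nM

In a functional assay for antagonist activity at adenosine receptor A2b (Homo sapiens) (on this read-out higher numbers stand for weaker inhibition and lower numbers for stronger inhibition), compound 1 has the lowest number of the two compounds, and compound 2 sits well apart from it, beyond the usual scatter. Compound 3, `CCCn1c(=O)c2nc(-c3ccc(O)nc3)[nH]c2n(CCC)c1=O`, is not yet measured. It differs from compound 1 by one change: hydrogen in place of ((4-fluorophenyl)carbamoyl)methyl on an oxygen on an aromatic ring. Only the shared core and the hydroxypyridine remain. Within the data shown here, no measured pair shows this exact step, so the expectation is an inference. Removing a group of this size is expected to weaken inhibition beyond the scatter, so the step of a 10-fold higher number from compound 1 to compound 3 (1.02 log units; beyond the scatter) is estimated to go upward. Compound 3 is expected to give about 50 nM, within 10 nM to 300 nM.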

Compound 3, inhibition constant: 4.9 nM
Compound 3: the middle estimate sits 10-fold (1.01 log units) above what was measured; measured number below the stated range.
By their numbers in this assay, from the lowest: compounds 1 and 3 (each within the scatter of the next); then compound 2.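

On the oxygen on an aromatic ring, hydrogen in place of ((4-fluorophenyl)carbamoyl)methyl gives a step in this assay (a 1.0-fold higher number from compound 1 to compound 3 (0.01 log units; within the scatter)). In this pair, then, all 11 heavy atoms of that group, including its six-membered aromatic ring, can go with no difference beyond the scatter, so compound 1 does not need this side chain to reach its number. Nothing available explains this result. Still open, going by these compounds, is whether a small group on that oxygen, such as methyl, would behave the same way, and whether an amine could take the place of the oxygen.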